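One methyl added on a chain carbon

The source may hold more compounds than are shown below. What is called first, only, known or untested is meant among the compounds shown, and "the series" means these compounds.

Values measured so far in a functional assay on MT4 cells (Homo sapiens) for cytotoxicity (a lower number here means that less compound is tolerated, a higher number that more compound is tolerated), are these:
Compound 1 `CCC(c1cc(O)nc(SC(C)C)n1)c1cccc2ccccc12` gives 16900 nM
Compound 2 `CC(c1cc(O)nc(SC2CCCC2)n1)c1cccc2ccccc12` gives 93000 nM

Compound 2, at 93000 nM in this pair, holds the higher of the two numbers, so more of it is tolerated. Compound 1 lies lower, and the gap goes beyond the usual scatter of repeated measurements.

The next molecule is compound 3 `CCC(c1cc(O)nc(SC2CCCC2)n1)c1cccc2ccccc12`, which has not been measured yet. It differs from compound 2 by a single change, (methyl in place of hydrogen on a saturated chain carbon, two bonds along the chain from two aromatic carbons), which is methyl in place of hydrogen on a saturated chain carbon, two bonds along the chain from two aromatic carbons. The same difference also reads as methyl to ethyl.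

Among the measured compounds shown here, no measured pair shows this change on its own, so any forecast is rough. With compound 1 at 16900 nM as the only other reference, a moderate fall in this assay is expected rather than a rise. The estimate amounts to an expected 2.1-fold lower number from compound 2 to compound 3 (0.32 log units; beyond the scatter) in this number. For compound 3 the estimated value is 45000 nM with an expected range from 15000 nM to 110000 nM across repeat measurements.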

Compound 3, half-maximal cytotoxic concentration: > 200000 nM
Compound 3 gave a limit, no number; the forecaster's own chance of this, stated with the estimate: 15%; at least 4.4-fold (0.64 log units) between middle value and limit.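

In this assay compound 3 gives a limit and not a number: the limit of > 200000 nM in this assay, at which 1 of the 3 values shown sits.

Among the compounds shown here, this is the first reading of methyl in place of hydrogen on a saturated chain carbon, two bonds along the chain from two aromatic carbons, and with the cyclopentyl group held constant the change gives an at least 2.1-fold higher number from compound 2 to compound 3 (0.33 log units; beyond the scatter), so more compound is tolerated after the change, not less. The sulfur group can also now be read on its own with the ethyl group held constant, as cyclopentyl in place of isopropyl on a sulfur gives an at least 11-fold higher number from compound 1 to compound 3 (1.07 log units; beyond the scatter), which the first two compounds could not show since they differ in two places.

On these data alone, each change rests on a single pair, so it remains open whether the methyl step would look the same with isopropyl on the sulfur, and the full size of both steps remains unknown. The compounds shown also leave open what a longer chain such as propyl, or an amine, at that chain carbon would do to the tolerated concentration.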